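Cyclopropyl gives way to 1H-benzimidazol-2-yl

This account rests on a few compounds, and the source may have more. Where it says the series, first, only, none or still open, it means among the compounds named here.

Measured in a toxicity assay on GES1 cells (Homo sapiens) for inhibition, read by MTT assay, with a stated time of 72 h; a lower number here means a stronger inhibitor, a higher number a weaker inhibitor:
- Compound 1 `Cc1cc(N2CC[C@@H](C)[C@@H](N(C)c3ncnc4[nH]ccc34)C2)n2nc(SCc3ccccc3)nc2n1`: 67200 nM
- Compound 2 `Cc1cc(N2CC[C@@H](C)[C@@H](N(C)c3ncnc4[nH]ccc34)C2)n2nc(SCc3ccc(Cl)cc3)nc2n1`: > 100000 nM
- Compound 3 `Cc1cc(N2CC[C@@H](C)[C@@H](N(C)c3ncnc4[nH]ccc34)C2)n2nc(SCC3CC3)nc2n1`: 27900 nM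

The entry for compound 2 is a limit of the assay, not a number. Of the two true numbers, compound 3 has the lower, 27900 nM. Compound 4 `Cc1cc(N2CC[C@@H](C)[C@@H](N(C)c3ncnc4[nH]ccc34)C2)n2nc(SCc3nc4ccccc4[nH]3)nc2n1` carries one change, 1H-benzimidazol-2-yl in place of cyclopropyl on a saturated chain carbon bound to a sulfur. Among the compounds with values here, two measured steps bear on this, both replacing an aromatic group with cyclopropyl: a 2.4-fold lower number from compound 1 to compound 3 (0.38 log units; beyond the scatter) and an at least 3.5-fold lower number from compound 2 to compound 3 (0.55 log units; beyond the scatter). Within the data shown here, compound 4 brings an aromatic group back, so a modest rise in this assay is expected, although no measured compound carries this group. For compound 4 the estimated value is 60000 nM, with an expected range of 20000 nM to 100000 nM. This estimate means an expected 2.2-fold higher number from compound 3 to compound 4 (0.33 log units; beyond the scatter).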

Compound 4, half-maximal inhibitory concentration: 40200 nM
Compound 4: the middle estimate sits 1.5-fold (0.17 log units) above what was measured, and the stated range covers the measured number.
By their numbers in this assay, from the lowest: compounds 3, 4 and 1 (each within the scatter of the next, the first and the last beyond it). At a limit, above all of these: compound 2.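

An aromatic group on a saturated chain carbon bound to a sulfur need not clearly raise the number in this assay: there is a 1.4-fold higher number from compound 3 to compound 4 (0.16 log units; within the scatter), and a 1.7-fold lower number from compound 1 to compound 4 (0.22 log units; within the scatter), so 1H-benzimidazol-2-yl cannot be told apart from either cyclopropyl or phenyl here. The remaining step rests on a limit, not a number, and so gives only a floor, an at least 2.4-fold lower number from compound 2 to compound 4 (0.39 log units; beyond the scatter): the limit of > 100000 nM in this assay, at which 1 of the 4 values shown sits.

The compounds shown leave open how an amine or a carboxylic acid would read at this place. They also leave open whether a pyridine ring would read like phenyl or like 1H-benzimidazol-2-yl.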